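Working notes: bromo in place of methoxy

The source may hold more compounds than are shown below. What is called first, only, known or untested is meant among the compounds shown, and "the series" means these compounds.

Among the measured compounds shown here, compound 1 `COc1ccccc1COc1ccccc1/C=C/C=C1\SC(=S)NC1=O` gives 98% in a functional assay on DLD-1 cells (Homo sapiens), read by microscopy and crystal violet staining, with a stated time of 20 h, tested at 10 ug/mL (on this read-out lower numbers stand for less inhibition and higher numbers for more inhibition at the one concentration tested (going by the name of the read-out)), the highest of the two numbers so far; compound 2 `O=C1NC(=S)S/C1=C\C=C\c1cccnc1` gives 45% in this assay, a gap beyond the scatter. Compound 3 `O=C1NC(=S)S/C1=C\C=C\c1ccccc1OCc1ccccc1Br` differs from compound 1 by bromo in place of methoxy on an aromatic carbon. For the measured compounds named here, no measured pair shows this change, so its size is open; a step of at most modest size is expected in this assay, downward or none beyond the scatter, since compound 1 already gives 98%. Compound 3 is estimated at 90%, range 70% to 100%, a step of a number 8 percentage points lower from compound 1 to compound 3 (within the scatter).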

Compound 3, a percentage reported as inhibition, at one concentration (the size of the read-out at that concentration, not a potency): 78%
Compound 3: the middle estimate sits 12 percentage points above what was measured; low and high end bracket the measured number.
By their numbers in this assay, from the lowest: compound 2; then compound 3; then compound 1.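

Bromo in place of methoxy on this aromatic carbon, ortho to a large group, gives the first measured step at this position: a number 20 percentage points lower from compound 1 to compound 3 (beyond the scatter) in this assay. The group here therefore affects the read-out, yet compound 3 still gives 78%, so the change lowers inhibition without abolishing it. Among the compounds shown here, nothing measured so far explains the step.

From the compounds shown here alone, whether an amine, a hydroxy group or a chloro group at this position would stay nearer compound 1 remains open. A single pair also cannot show whether this step would recur on another core.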